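The compounds below may be only part of what the source reports. "The series", "measured", "known", "first", "only" and "open" are said of these compounds alone.

Measured so far:
- compound 1, `O=C(CCC(=O)c1cccs1)NCCCO`, gives 300 mg/kg
- compound 2, `O=C1CCC2(c3ccc(F)cc3)OCCCN12`, gives 75 mg/kg
- compound 3, `Cc1ccc(C23CCC(=O)N2CCCO3)c(C)c1`, gives < 50 mg/kg

In a functional assay on the whole organism (Central nervous system) for activation, with Mus musculus as the target (on this read-out higher numbers stand for an effect only at larger amounts of compound and lower numbers for an effect already at smaller amounts), compound 2 stands at 75 mg/kg, the lower of the two plain numbers, and its gap to compound 1 at 300 mg/kg lies beyond the usual scatter. For compound 3 the result of < 50 mg/kg is a limit of the assay rather than a number, as shown by the limit of < 50 mg/kg in this assay, at which 1 of the 3 values shown sits.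

Compound 4, `O=C1CCC2(c3ccccc3)OCCCN12`, has not yet been measured. It differs from compound 2 in one place: hydrogen in place of fluoro on an aromatic carbon. Going by the values given here, no measured pair of compounds shows this same change, so its effect cannot be read from the data. The expectation is that compound 4 stays close to compound 2, with a step of a 1.3-fold higher number from compound 2 to compound 4 (0.12 log units; within the scatter) that does not go beyond the scatter. The estimate for compound 4 in this assay is therefore 100 mg/kg, with a range from 40 mg/kg to 250 mg/kg.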

Compound 4, dose for half-maximal effect: 37.5 mg/kg
For compound 4 the middle estimate is 2.7-fold (0.43 log units) above the measured one; the whole stated range lies above it.
By their numbers in this assay, from the lowest: compounds 4 and 2 (each within the scatter of the next); then compound 1.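

In this assay, swapping fluoro for hydrogen on an aromatic carbon, para to a large group, gives a 2.0-fold lower number from compound 2 to compound 4 (0.30 log units; within the scatter). Going by these compounds alone, this is the first direct comparison at this position, since the earlier compounds include no pair differing in one place, and it shows that the fluoro is not needed for the effect: with hydrogen in its place, the result cannot be told apart from that of the fluoro compound. Nothing shown accounts for the size of this step.

This single pair leaves open how the same position responds to a group of another kind, such as a methoxy group, an amine or a carboxylic acid. It also leaves open whether swapping fluoro for hydrogen would give a similar result on another core.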